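Replacing the Naphthyl Head of Compound 1 with Methoxyphenyl

A few compounds are considered here, and "the series" means these few. Any claim that something is new, unique, unknown or untested is made for them only; others in the source may bear on it.

Three compounds have been measured in a functional assay on MIA PaCa-2 cells (Homo sapiens) for inhibition, read by MTT assay, with a stated time of 72 h; a higher number here means a weaker inhibitor of growth, a lower number a stronger inhibitor of growth:

Compound 1 `O=S(=O)(NCCCNCc1cccc2ccccc12)c1cc(C(F)(F)F)cc(C(F)(F)F)c1` gives 2800 nM
Compound 2 `O=S(=O)(NCCCCCCNCc1ccc(Br)cc1)c1c(Cl)cccc1Cl` gives 14700 nM
Compound 3 `O=S(=O)(NCCCCCCNCc1ccc(Br)cc1)c1cc(Cl)cc(Cl)c1` gives 12000 nM

Compound 1 gives the lowest number of the three; both compound 2 and compound 3 stand well above it, beyond the scatter. Compounds 2 and 3 differ only in the aryl on the sulfonyl sulfur, and that change gave a 1.2-fold lower number from compound 2 to compound 3 (0.09 log units; within the scatter).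

Compound 4 `COc1ccc(CNCCCNS(=O)(=O)c2cc(C(F)(F)F)cc(C(F)(F)F)c2)cc1` is compound 1 with one change: 4-methoxyphenyl in place of naphthalen-1-yl on a saturated chain carbon bound to an amine nitrogen. Going by the values given here, no measured step touches this position; the one measured step lies on the sulfonyl aryl and stays within the scatter, so it gives no guide here. Without a precedent, the expected step of a 1.8-fold higher number from compound 1 to compound 4 (0.25 log units; within the scatter) is a modest rise carrying wide uncertainty. Compound 4 is therefore estimated at 5000 nM, with a likely range from 1500 nM to 16000 nM.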

Compound 4, concentration for 50% growth inhibition: 2500 nM
Estimate against measurement, compound 4: 2.0-fold (0.30 log units) above, and the stated range covers the measured number.
By their numbers in this assay, from the lowest: compounds 4 and 1 (each within the scatter of the next); then compounds 3 and 2 (each within the scatter of the next).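

Swapping naphthalen-1-yl for 4-methoxyphenyl on a saturated chain carbon bound to an amine nitrogen gave a 1.1-fold lower number from compound 1 to compound 4 (0.05 log units; within the scatter) in this assay and so showed that, with this sulfonyl aryl and this chain, the second aromatic ring is not needed to keep this level of growth inhibition. Nothing measured here explains why the two groups give matching numbers. Still open, as far as these compounds go, is whether the methoxy group matters at all, which an unsubstituted phenyl or a 4-hydroxyphenyl at this position would help to test. Also open, from the compounds shown here alone, is whether the two groups would still match on a longer chain.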